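Swapping a trifluoromethylphenyl for a methylindole

The source may hold more compounds than are shown below. What is called first, only, known or untested is meant among the compounds shown, and "the series" means these compounds.

Values so far in a functional assay on A549 cells (Homo sapiens) for inhibition, read by CCK-8 assay, with a stated time of 48 h; on this read-out higher numbers stand for weaker inhibition and lower numbers for stronger inhibition
compound 1 `COc1cc(-c2ccnc3cc(-c4ccc(F)cc4)nn23)cc(OC)c1OC` gives 3800 nM
compound 2 `COc1cc(-c2ccnc3cc(-c4ccc(C)c(C)c4)nn23)cc(OC)c1OC` gives 272 nM
compound 3 `COc1cc(-c2ccnc3cc(-c4ccc(C(F)(F)F)cc4)nn23)cc(OC)c1OC` gives 2070 nM

Compound 3 sits at the weaker end of this small set, as a 1.8-fold lower number from compound 1 to compound 3 (0.26 log units; within the scatter) and a 7.6-fold higher number from compound 2 to compound 3 (0.88 log units; beyond the scatter) show. The next structure, compound 4 `COc1cc(-c2ccnc3cc(-c4cn(C)c5ccccc45)nn23)cc(OC)c1OC`, differs from it as follows: 1-methyl-1H-indol-3-yl in place of 4-(trifluoromethyl)phenyl on an aromatic carbon, which puts 1-methyl-1H-indol-3-yl in place of 4-(trifluoromethyl)phenyl on an aromatic carbon. Among the measured compounds shown here, no measured compound carries this new group, so the guides are indirect. Changes at that same carbon have mattered, with a 14-fold lower number from compound 1 to compound 2 (1.15 log units; beyond the scatter) being large. For the measured compounds named here, compound 2 gives 272 nM and is the only measured compound without fluorine in that group, which is also true of compound 4. A move to stronger inhibition is therefore expected, and the estimated step is a 5.9-fold lower number from compound 3 to compound 4 (0.77 log units; beyond the scatter) in this read-out. Compound 4 is estimated at 350 nM, with an expected range from 70 nM to 1800 nM in this assay for this untested compound.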

Compound 4, half-maximal inhibitory concentration: 1340 nM
Compound 4: middle estimate off by 3.8-fold (0.58 log units), on the low side; the range from low to high includes it.
By their numbers in this assay, from the lowest: compound 2; then compounds 4, 3 and 1 (each within the scatter of the next, the first and the last beyond it).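

Having no fluorine in this group does not by itself give the inhibition seen with compound 2: in this assay, 1-methyl-1H-indol-3-yl shows a 4.9-fold higher number from compound 2 to compound 4 (0.69 log units; beyond the scatter) and, staying within the scatter, a 1.5-fold lower number from compound 3 to compound 4 (0.19 log units; within the scatter) against 4-(trifluoromethyl)phenyl. It does separate from 4-fluorophenyl, with a 2.8-fold lower number from compound 1 to compound 4 (0.45 log units; beyond the scatter) at the same carbon. Nothing available here explains these differences. Still open, going by these compounds, is what a phenyl ring carrying an amine or a methoxy group would do at this carbon, and whether an indole without its methyl would behave like compound 4.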